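A few compounds are considered here, and "the series" means these few. Any claim that something is new, unique, unknown or untested is made for them only; others in the source may bear on it.

Compound 1 `CNC(=O)c1cc(Oc2ccc(C(=O)/C=C/c3cccc(Br)c3)cc2)ccn1`: 2870 nM
Compound 2 `CNC(=O)c1cc(Oc2ccc(C(=O)/C=C/c3ccc(Br)cc3)cc2)ccn1`: > 50000 nM (a limit)
Compound 3 `CNC(=O)c1cc(Oc2ccc(C(=O)/C=C/c3ccccc3)cc2)ccn1`: 6640 nM

In a functional assay on HepG2 cells (Homo sapiens) for cytotoxicity, read by MTT assay, with a stated time of 72 h (a lower number here means a stronger inhibitor, a higher number a weaker inhibitor), compound 3 gives 6640 nM, the higher of the two actual numbers. The value of compound 2 is a limit. The nearest number belongs to compound 1, and hydrogen in place of its bromo gives a 2.3-fold higher number from compound 1 to compound 3 (0.36 log units; beyond the scatter).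

Compound 4 `CNC(=O)c1cc(Oc2ccc(C(=O)/C=C/c3ccc(Cl)cc3Cl)cc2)ccn1` carries 2,4-dichlorophenyl in place of the phenyl of compound 3, on a double-bonded chain carbon bound to a double-bonded chain carbon (2,4-dichlorophenyl in place of phenyl on a double-bonded chain carbon bound to a double-bonded chain carbon). Within the data shown here, no chlorinated compound has been measured yet, so the bromo steps are the only guide, and they do not agree. Moving from 3-bromophenyl to 4-bromophenyl gives an at least 17-fold higher number from compound 1 to compound 2 (1.24 log units; beyond the scatter), a large step. Hydrogen in place of the bromo of 4-bromophenyl gives an at least 7.5-fold lower number from compound 2 to compound 3 (0.87 log units; beyond the scatter). Halogen on this ring can therefore push the number either way.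

Compound 2, whose 4-bromophenyl is the closer match to 2,4-dichlorophenyl, stands at the limit of > 50000 nM. A higher number in this assay is therefore expected, though with much uncertainty. The expected change is a 2.0-fold higher number from compound 3 to compound 4 (0.29 log units; within the scatter). For compound 4 the estimate is 13000 nM, with an expected range of 3000 nM to 50000 nM.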

Compound 4, half-maximal inhibitory concentration: 11700 nM
The estimate for compound 4 lay 1.1-fold (0.05 log units) above the measured number; measured number inside the range.
By their numbers in this assay, from the lowest: compound 1; then compounds 3 and 4 (each within the scatter of the next). At a limit, above all of these: compound 2.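

In this assay, adding 2,4-dichlorophenyl in place of phenyl leaves the number within the scatter: a 1.8-fold higher number from compound 3 to compound 4 (0.25 log units; within the scatter). So a halogen on this ring, even two of them, need not bring the collapse seen with 4-bromophenyl, as an at least 4.2-fold lower number from compound 2 to compound 4 (0.63 log units; beyond the scatter) shows, although that step leans on a limit and not on a true number: the limit of > 50000 nM in this assay, at which 1 of the 4 values shown sits. The 3-bromophenyl ring of compound 1 also keeps a real edge over the new ring, with a 4.1-fold higher number from compound 1 to compound 4 (0.61 log units; beyond the scatter), so among the halogenated compounds the result depends on which halogen is present and how the ring is substituted, not on the mere presence of halogen.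

Going by these compounds, what each chlorine contributes stays open, and a 2-chlorophenyl or a 4-chlorophenyl ring on the same chain carbon would separate the two, while a 3-chlorophenyl ring would test whether the edge of compound 1 carries over from bromo to chloro. On these data alone, whether anything other than halogen is tolerated on this ring also remains unknown, for example a methoxy group, an amine or a carboxylic acid.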